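Phenyl for difluorophenyl on the urea nitrogen

The compounds below may be only part of what the source reports. "The series", "measured", "known", "first", "only" and "open" are said of these compounds alone.

Measured so far:
Compound 1 `Cc1ccccc1NC(=O)Nc1cc(C(C)(C)C)nn1-c1ccccc1`, in an assay on isolated protein for inhibition of Ephrin type-A receptor 2 (Homo sapiens), read by thermal shift assay, tested at 10 uM (on this read-out higher numbers stand for stronger stabilisation of the target against heat and lower numbers for weaker stabilisation of the target), compound 1 gives 1.2 degrees C.
Compound 2 `CC(C)(C)c1cc(NC(=O)Nc2ccc(F)c(F)c2)n(-c2ccccc2)n1`, in this assay compound 2 gives 2.2 degrees C.

Compound 2 stands highest of the two numbers, but its nearest neighbour compound 1 lies within the scatter, a number 1.0 degrees C higher from compound 1 to compound 2 (within the scatter).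

Compound 3 `CC(C)(C)c1cc(NC(=O)Nc2ccccc2)n(-c2ccccc2)n1` differs from compound 2 by phenyl in place of 3,4-difluorophenyl on an amide-type nitrogen. Among the compounds with values here, no measured step covers this exact change; the only step known, from compound 1 to compound 2, also altered the group on the amide-type nitrogen and stayed within the scatter. The expectation for compound 3 is therefore no step beyond the scatter, a number 0.50 degrees C lower from compound 2 to compound 3 (within the scatter). Compound 3 is estimated at 1.7 degrees C, range 0.5 degrees C to 3 degrees C.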

Compound 3, shift of the target's melting temperature: 1.6 degrees C
Compound 3: middle estimate off by 0.10 degrees C, on the high side, within the range that was stated.
By their numbers in this assay, from the lowest: compounds 1, 3 and 2 (each within the scatter of the next).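

In this assay, phenyl in place of 3,4-difluorophenyl on the amide-type nitrogen gives a number 0.60 degrees C lower from compound 2 to compound 3 (within the scatter) and so does not separate these two compounds. Hydrogen in place of methyl on the aromatic carbon gives a number 0.40 degrees C higher from compound 1 to compound 3 (within the scatter) and does not separate those two either, so all three aryl groups on this nitrogen remain within the scatter of their neighbours. No available evidence bears on why the numbers stay so close.

Still open, on these data alone, is whether any group at this position gives a step beyond the scatter. A carboxylic acid or an amine on the phenyl, or a longer chain in place of it, would test that.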